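Losing the chloro from compound 1

This account rests on a few compounds, and the source may have more. Where it says the series, first, only, none or still open, it means among the compounds named here.

In a physicochemical assay for inhibition, with a stated time of 7 days (on this read-out higher numbers stand for weaker inhibition and lower numbers for stronger inhibition), compound 1 (`Cc1ccc(NC(=O)Nc2cccc(Cl)c2)c(C)c1`) has no single number and is reported as "not active" (no number reported) on this read-out. Compound 3 (`Cc1ccc(NC(=O)Nc2cccc(Cl)c2)cc1C`) is likewise reported as "not active" (no number reported) and offers no number either. Only compound 2 (`Cc1cc(C)cc(NC(=O)Nc2cccc(Cl)c2)c1`) gives a number, 906000 nM on the same read-out. The unmeasured compound 4 (`Cc1ccc(NC(=O)Nc2ccccc2)c(C)c1`) differs from compound 1 in one place (hydrogen in place of chloro on an aromatic carbon), with hydrogen in place of chloro on an aromatic carbon. Going by the values given here, no measured step shows what this change does, so no step toward stronger inhibition beyond the scatter is expected in this assay here. Compound 4 is expected at 900000 nM with an estimated range from 400000 nM to 2000000 nM. Compound 4 may also be expected to end up without a single number.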

Compound 4, half-maximal inhibitory concentration: "not active" (no number reported)
Nothing numeric was reported for compound 4, and the estimate cannot be compared.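

Compound 1 and compound 4 both stand without a number, so no step can be read between them. No supporting evidence bears on this result. From the compounds shown here alone, what hydrogen in place of chloro does to inhibition stays open.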